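The source may hold more compounds than are shown below. What is called first, only, known or untested is meant among the compounds shown, and "the series" means these compounds.

Of the compounds shown here, three that share a core have been measured so far in a physicochemical assay for solubility, read by spectrophotometry, measured as kinetic solubility, at pH 8, tested at 500 uM; a higher number here means a more soluble compound, a lower number a less soluble compound. Compound 1 `CN1CCCC(NS(=O)(=O)c2ccccc2Nc2cc(-c3ccc4ccn(C)c4c3)c3nccnc3c2)C1` gives 9 ug/mL, compound 2 `CN1CCC(NS(=O)(=O)c2ccccc2Nc2cc(-c3ccc4ccn(C)c4c3)c3nccnc3c2)C1` gives 26 ug/mL, and compound 3 `CN(C)C(=O)c1ccncc1Nc1cc(-c2ccc3ccn(C)c3c2)c2nccnc2c1` gives 175 ug/mL, the highest number of the three and clearly above both others. Compound 4 `CN1CCC(NC(=O)c2ccncc2Nc2cc(-c3ccc4ccn(C)c4c3)c3nccnc3c2)CC1=O` keeps the core of compound 3 and differs at a single place: (1-methyl-2-oxopiperidin-4-yl)amino in place of dimethylamino on a carbonyl carbon. Thus (1-methyl-2-oxopiperidin-4-yl)amino stands in place of dimethylamino on a carbonyl carbon.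

Among the measured compounds shown here, only one measured step is available, and it bears on this change only indirectly. It is a 2.9-fold higher number from compound 1 to compound 2 (0.46 log units; beyond the scatter), a modest move beyond the scatter, and it was made on a sulfonamide nitrogen rather than on a carbonyl carbon. For the measured compounds named here, no measured step shows what a change on the carbonyl carbon does. Still, that step shows that exchanging one ring substituent for another can shift the number in this assay, so a modest step is expected here as well. Its direction is less certain, but a lower number is the more likely outcome, since compound 3 already stands at the top of the measured set with 175 ug/mL. The estimated step is a 2.2-fold lower number from compound 3 to compound 4 (0.34 log units; beyond the scatter). For compound 4 the expected value is 80 ug/mL, with an estimated range from 25 ug/mL to 220 ug/mL.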

Compound 4, solubility: 48 ug/mL
Compound 4: middle estimate off by 1.7-fold (0.22 log units), on the high side; low and high end bracket the measured number.
By their numbers in this assay, from the lowest: compound 1; then compounds 2 and 4 (each within the scatter of the next); then compound 3.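

In this assay the carbonyl carbon now has a measured step of its own, which reads a 3.6-fold lower number from compound 3 to compound 4 (0.56 log units; beyond the scatter) on placing (1-methyl-2-oxopiperidin-4-yl)amino where dimethylamino stood. Among the compounds shown here, the earlier compounds showed a change only on a sulfonamide nitrogen, where the number rose, so this is the first sign that the group on the carbonyl carbon also moves the number, and here it moves it down, with an entering group that brings one six-membered non-aromatic ring, one hydrogen-bond donor and one hydrogen-bond acceptor that dimethylamino does not have. Nothing available bears on what lies behind this fall, so it stands as an observation only.

From the compounds shown here alone, this single exchange alters the ring, the ring carbonyl and the amide hydrogen all at once, so it remains open which of these goes with the lower number, and whether a small methylamino group or a 1-methylpiperidin-4-ylamino group without the ring carbonyl would land nearer compound 3 or compound 4. Also open, going by these compounds, is whether a basic amine on a longer chain, or a morpholine ring, on the same carbonyl carbon would raise the number again.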